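This account rests on a few compounds, and the source may have more. Where it says the series, first, only, none or still open, it means among the compounds named here.

Measured so far:
compound 1, `COc1cccc(CNCc2c(C(=O)O)n(Cc3ccc(C)cc3)c3cc(C)ccc23)c1`: 5290 nM
compound 2, `COc1cccc(CNCc2c(C(=O)O)n(Cc3ccccc3)c3cc(C(C)C)ccc23)c1`: 5090 nM
compound 3, `COc1ccc(Cn2c(C(=O)O)c(CNCc3cccc(O)c3)c3ccc(C)cc32)cc1`: 9910 nM

In a functional assay on SNU-387 cells (Homo sapiens) for antiproliferative activity, read by MTT assay, with a stated time of 72 h (a higher number here means a weaker inhibitor, a lower number a stronger inhibitor), compound 2 gives 5090 nM, the lowest of the three numbers. Compound 1 at 5290 nM sits practically on top of it, and compound 3 at 9910 nM is also within the usual scatter, so the three measured compounds cannot be ranked against one another; all three read as weak inhibitors of SNU-387 proliferation.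

Compound 4, `COc1cccc(CNCc2c(C(=O)O)n(Cc3ccc(N)cc3)c3cc(C(C)C)ccc23)c1`, has not been measured. It differs from compound 2 in one place: amino in place of hydrogen on an aromatic carbon. Going by the values given here, no pair of measured compounds differs by a single change, so there is no measured step to lean on, and none that shows what an amino group on that benzyl ring does. Among the compounds with values here, the three measured compounds, which vary the substituents on the benzyl and on the shared core, all stay within scatter of one another, which is the only hint available: the series so far looks flat.

Given that, the expectation for this assay is no step beyond the scatter, in neither direction. Compound 4 is expected to give about 5500 nM, with a range of 2500 nM to 12000 nM. The expected step is a 1.1-fold higher number from compound 2 to compound 4 (0.03 log units; within the scatter), inside the scatter.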

Compound 4, half-maximal inhibitory concentration: 9010 nM
Estimate against measurement, compound 4: 1.6-fold (0.21 log units) below, and the stated range covers the measured number.
By their numbers in this assay, from the lowest: compounds 2, 1, 4 and 3 (each within the scatter of the next).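

Working notes on the series: in this assay, the first single-change step available reads a 1.8-fold higher number from compound 2 to compound 4 (0.25 log units; within the scatter), for amino in place of hydrogen on an aromatic carbon, para to a large group. Going by these compounds alone, this shows directly what the earlier compounds could only hint at, since they differ from one another in more than one place: on this background, going from benzyl to 4-aminobenzyl produces no step beyond the scatter, so the position accepts this one change without a readable shift in either direction. No measured property of these compounds bears on this result, and the step alone offers no account of it.

The compounds shown leave open whether a different group on the same aromatic carbon, such as a nitrile, a trifluoromethyl or an acetamide, would give a step beyond the scatter, or whether this series stays flat there as well. From the compounds shown here alone, it also remains open whether amino on the benzyl ring reads the same way with the smaller methyl substituent on the core of compound 1, or whether a longer chain ending in an amine behaves like amino itself.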